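Chloro to Bromo on the Pendant Phenyl

The source may report more compounds than this note shows. Statements on the series, on what has been measured and on what is new or still open speak of the compounds shown alone.

Compound 1, `Cn1ccc2c(Oc3ccc(NC(=O)c4cc5cccnc5n(-c5ccccc5)c4=O)cc3)ccnc21`, is the reference point of this pair. In a functional assay on HT-29 cells (Homo sapiens) for antiproliferative activity, read by MTT assay, with a stated time of 72 h (a higher number here means a weaker inhibitor, a lower number a stronger inhibitor), compound 1 gives 620 nM. Compound 2, `Cn1ccc2c(Oc3ccc(NC(=O)c4cc5cccnc5n(-c5ccc(Cl)cc5)c4=O)cc3)ccnc21`, carries chloro in place of hydrogen on an aromatic carbon, and in this assay compound 2 gives 730 nM. For the measured compounds named here, the one step measured so far, a 1.2-fold higher number from compound 1 to compound 2 (0.07 log units; within the scatter), falls within the scatter. Compound 2 thus holds the higher of the two numbers, with compound 1 nearest and within the scatter of it.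

Compound 3, `Cn1ccc2c(Oc3ccc(NC(=O)c4cc5cccnc5n(-c5ccc(Br)cc5)c4=O)cc3)ccnc21`, differs from compound 2 by bromo in place of chloro on an aromatic carbon. Going by the values given here, the only step that bears on this change is the halogen-for-hydrogen step from compound 1 to compound 2, and it was within the scatter. Compound 3 is therefore expected to show no step beyond the scatter, a 1.0-fold higher number from compound 2 to compound 3 (0.01 log units; within the scatter), and its estimated value in this assay is 750 nM, with a range from 400 nM to 1400 nM.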

Compound 3, half-maximal inhibitory concentration: 690 nM
Estimate against measurement, compound 3: 1.1-fold (0.04 log units) above; the range from low to high includes it.
By their numbers in this assay, from the lowest: compounds 1, 3 and 2 (each within the scatter of the next).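

In this assay a second halogen at this place, para to a large group, also stays within the scatter: the exchange of chloro for bromo gives (a 1.1-fold lower number from compound 2 to compound 3 (0.02 log units; within the scatter)), and bromo in place of hydrogen gives (a 1.1-fold higher number from compound 1 to compound 3 (0.05 log units; within the scatter)). For the compounds shown here, the single chloro step could not show this, but now hydrogen, chloro and bromo at this place all lie within the scatter of one another, so compound 1, compound 2 and compound 3 cannot be told apart in this assay. No measurement beyond these numbers bears on this result.

Going by these compounds, whether the same holds for a group of another kind at this place, such as an amine, a carboxylic acid or a longer alkyl chain, stays open. So does whether chloro or bromo on another carbon of that ring would give a number of the same size.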